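Fluorinated aniline in place of a methylated one

The source may hold more compounds than are shown below. What is called first, only, known or untested is meant among the compounds shown, and "the series" means these compounds.

Compound 1 `CCc1ccccc1NS(=O)(=O)c1ccc(N2CCNC2=O)cc1`: 350 nM
Compound 2 `CCc1ccc(NS(=O)(=O)c2ccc(N3CCNC3=O)cc2)cc1`: 810 nM
Compound 3 `Cc1ccccc1NS(=O)(=O)c1ccc(N2CCNC2=O)cc1`: 280 nM

These three compounds share one core and differ only in the aryl group on the sulfonamide nitrogen. Measured in a functional assay on MCF7 cells (Homo sapiens) for antiproliferative activity, read by sulforhodamine B assay, with a stated time of 48 h (on this read-out higher numbers stand for weaker inhibition and lower numbers for stronger inhibition), compound 3 gives the lowest number of the three. Its nearest neighbour is compound 1, separated by a 1.3-fold lower number from compound 1 to compound 3 (0.10 log units; within the scatter), which lies within the scatter, so the two cannot be ordered. Compound 2 stands furthest away, separated by a 2.9-fold lower number from compound 2 to compound 3 (0.46 log units; beyond the scatter), which lies beyond it.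

Compound 4 `O=C1NCCN1c1ccc(S(=O)(=O)Nc2ccc(F)c(F)c2)cc1` has not yet been measured. It differs from compound 3 by 3,4-difluorophenyl in place of 2-methylphenyl on a sulfonamide nitrogen.

For the measured compounds named here, two measured steps bear on this change. The step of a 2.3-fold higher number from compound 1 to compound 2 (0.36 log units; beyond the scatter), 2-ethylphenyl to 4-ethylphenyl, and the step of a 2.9-fold lower number from compound 2 to compound 3 (0.46 log units; beyond the scatter), 4-ethylphenyl to 2-methylphenyl, both show the 2-ethylphenyl and 2-methylphenyl compounds giving the lower numbers and the 4-ethylphenyl compound the higher one. Going by the values given here, the 3,4-difluorophenyl of compound 4 carries no group of the kind seen in 2-methylphenyl, and no measured compound shows how fluorine behaves here. A modest rise in this assay, about the size of those two steps, is therefore expected for compound 4: a 2.3-fold higher number from compound 3 to compound 4 (0.37 log units; beyond the scatter). Compound 4 is estimated at 650 nM, with a range from 250 nM to 1700 nM.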

Compound 4, half-maximal inhibitory concentration: 620 nM
Compound 4: the middle estimate sits 1.0-fold (0.02 log units) above what was measured; measured number inside the range.
By their numbers in this assay, from the lowest: compounds 3, 1, 4 and 2 (each within the scatter of the next, the first and the last beyond it).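

In this assay, for the compounds shown here, placing 3,4-difluorophenyl on the sulfonamide nitrogen in place of 2-methylphenyl gives a 2.2-fold higher number from compound 3 to compound 4 (0.35 log units; beyond the scatter) and so shows for the first time how a fluorinated aryl group fares at this position. Compound 4 cannot be ordered against the two ethylphenyl compounds: a 1.3-fold lower number from compound 2 to compound 4 (0.12 log units; within the scatter) and a 1.8-fold higher number from compound 1 to compound 4 (0.25 log units; within the scatter) both lie within the scatter, even though those two compounds stand apart from each other by a 2.3-fold higher number from compound 1 to compound 2 (0.36 log units; beyond the scatter) in the same assay. No measurement available here accounts for the rise from compound 3 to compound 4.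

Compound 4 differs from compound 3 by losing the methyl group and gaining two fluorines in a single change, so the compounds shown cannot assign the rise to either part of that exchange. As far as these compounds go, how an unsubstituted phenyl, a phenyl carrying a single fluorine, or a ring bearing a chlorine, a methoxy group or an amine would read at this position also remains open.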